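The source may report more compounds than this note shows. Statements on the series, on what has been measured and on what is new or still open speak of the compounds shown alone.

Measured compounds:
- compound 1 `Cc1ccc(S(=O)(=O)/N=C(/CCNC2=CC(=O)c3ccccc3C2=O)Nc2ccc(F)c(F)c2)cc1`: 8790 nM
- compound 2 `COc1ccc(N/C(CCNC2=CC(=O)c3ccccc3C2=O)=N\S(=O)(=O)c2ccc(C)cc2)c(OC)c1`: 67600 nM
- compound 3 `Cc1ccc(S(=O)(=O)/N=C(/CCNC2=CC(=O)c3ccccc3C2=O)Nc2ccc(Cl)cc2Cl)cc1`: 20500 nM

In a functional assay on HeLa cells (Homo sapiens) for cytotoxicity, read by MTT assay, with a stated time of 48 h (a lower number here means a stronger inhibitor, a higher number a weaker inhibitor), compound 3 gives 20500 nM, the second highest of the three numbers. Its nearest neighbour is compound 1 with 8790 nM, and its furthest is compound 2 with 67600 nM; the step of a 2.3-fold higher number from compound 1 to compound 3 (0.37 log units; beyond the scatter) and the step of a 3.3-fold lower number from compound 2 to compound 3 (0.52 log units; beyond the scatter) both lie beyond the scatter.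

Compound 4 `COc1cc(N/C(CCNC2=CC(=O)c3ccccc3C2=O)=N\S(=O)(=O)c2ccc(C)cc2)cc(OC)c1OC` differs from compound 3 in one place: 3,4,5-trimethoxyphenyl in place of 2,4-dichlorophenyl on an amine nitrogen.

Among the measured compounds shown here, two measured steps bear on this change. The step of a 7.7-fold higher number from compound 1 to compound 2 (0.89 log units; beyond the scatter) shows that a methoxy-bearing aryl group on this nitrogen gives a clearly higher number than a halogen-bearing one, and the step of a 3.3-fold lower number from compound 2 to compound 3 (0.52 log units; beyond the scatter) shows the reverse move, a dichlorophenyl in place of a dimethoxyphenyl, lowering the number. Both point the same way: the entry of methoxy groups on this aryl ring goes with weaker inhibition in this assay. For the measured compounds named here, compound 4 carries three methoxy groups, one more than compound 2, and no compound with a 3,4,5-trimethoxyphenyl has been measured, so the size of the step is uncertain.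

On this basis compound 4 is expected to give a higher number than compound 3, a step of roughly a 2.9-fold higher number from compound 3 to compound 4 (0.47 log units; beyond the scatter), landing near or above compound 2. The estimate for compound 4 is 60000 nM, with a range from 20000 nM to 200000 nM.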

Compound 4, half-maximal inhibitory concentration: 3390 nM
For compound 4 the middle estimate is 18-fold (1.25 log units) above the measured one; measured number outside the range, below it.
By their numbers in this assay, from the lowest: compound 4; then compound 1; then compound 3; then compound 2.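

In this assay, the 3,4,5-trimethoxyphenyl on this amine nitrogen gives the lowest number of the four, below both halogen-bearing compounds (a 6.0-fold lower number from compound 3 to compound 4 (0.78 log units; beyond the scatter); a 2.6-fold lower number from compound 1 to compound 4 (0.41 log units; beyond the scatter)), so compound 4 goes against the link between methoxy groups and weaker inhibition that compound 2 had suggested. The largest step in the series now lies between the two methoxy-bearing aryl groups (a 20-fold lower number from compound 2 to compound 4 (1.30 log units; beyond the scatter)), which shows that the presence of methoxy groups alone does not set the number at this position and that the whole substituted ring has to be read as one unit. No measurement on these compounds explains this reversal.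

Still open, on these data alone, is which part of the 3,4,5-trimethoxyphenyl carries the lower number, a question that a 3,5-dimethoxyphenyl, a 4-methoxyphenyl or an unsubstituted phenyl on the same nitrogen would help to settle. As far as these compounds go, it is also open whether the gain from this group would hold with a 3,4,5-trihydroxyphenyl in its place, or with a longer chain between the amine nitrogen and the rest of the core.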